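This account rests on a few compounds, and the source may have more. Where it says the series, first, only, none or still open, it means among the compounds named here.

Measured in an ADME assay on CCRF-HSB-2 cells (Homo sapiens) for cytotoxicity, with a stated time of 7 days; on this read-out lower numbers stand for higher toxicity in this test and higher numbers for lower toxicity in this test:
compound 1 `Nc1nc(NCc2ccccc2)c2ncn(/C=C3/CC3(CO)CO)c2n1`: > 20000 nM (a limit)
compound 2 `Nc1nc(NC2CC2)c2ncn(/C=C3/CC3(CO)CO)c2n1`: > 20000 nM (a limit)
compound 3 `CCCNc1nc(N)nc2c1ncn2/C=C1/CC1(CO)CO`: > 20000 nM (a limit)

Compound 3 stands at > 20000 nM, which is a limit and not a number. The whole series shares this position: the limit of > 20000 nM in this assay, at which 3 of the 3 values shown sit. Compound 4 `CSc1nc(N)nc2c1ncn2/C=C1/CC1(CO)CO` has methylsulfanyl in place of propylamino on an aromatic carbon. The nearest measured steps, a step that the two limits leave unreadable from compound 1 to compound 2, a step that the two limits leave unreadable from compound 1 to compound 3 and a step that the two limits leave unreadable from compound 2 to compound 3, have no readable size, and each keeps the nitrogen on the aromatic ring. Going by the values given here, no measured step therefore gives a size or direction for this exchange, so no clear step is expected in this assay. The expected step is a number no higher from compound 3 to compound 4 (the limit leaves the size open). For compound 4 the estimated value is 20000 nM, with an expected range from 6000 nM to 40000 nM.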

Compound 4, half-maximal cytotoxic concentration: > 100000 nM
Compound 4 gave a limit, no number (the forecaster's own chance of this, stated with the estimate: 70%); at least 5.0-fold (0.69 log units) between middle value and limit.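

Compound 4 gives > 100000 nM in this assay, a limit and not a number. Compound 1, compound 2 and compound 3 also stand at limits, so no step among these compounds can be read. The compounds shown leave open the size and direction of any effect of these exchanges on the shared core.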